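The source may report more compounds than this note shows. Statements on the series, on what has been measured and on what is new or still open speak of the compounds shown alone.

In a functional assay on BT-474 cells (Homo sapiens) for inhibition, read by MTT assay, with a stated time of 5 days (on this read-out lower numbers stand for stronger inhibition and higher numbers for weaker inhibition), compound 1 `Cc1cc(Nc2nc(NCc3ccccc3Cl)nc3[nH]ncc23)n[nH]1` gives 7160 nM and lies within the scatter of both of its measured relatives, compound 2 `Cc1cc(Nc2nc(NCc3ccc(Cl)cc3)nc3[nH]ncc23)n[nH]1` at 11700 nM and compound 3 `Cc1cc(Nc2nc(NCc3ccc(Br)cc3)nc3[nH]ncc23)n[nH]1` at 4110 nM on the same read-out. The steps that start from compound 1 are small: a 1.6-fold higher number from compound 1 to compound 2 (0.21 log units; within the scatter) and a 1.7-fold lower number from compound 1 to compound 3 (0.24 log units; within the scatter) are the two changes of this aromatic group on record. Only the swap of chloro for bromo, a 2.8-fold lower number from compound 2 to compound 3 (0.45 log units; beyond the scatter), goes beyond the scatter, and even that is modest. Compound 4 `Cc1cc(Nc2nc(NCc3ccc(F)cc3F)nc3[nH]ncc23)n[nH]1` has 2,4-difluorophenyl in place of 2-chlorophenyl on a saturated chain carbon bound to a nitrogen on an aromatic ring with the core unchanged. Among the compounds with values here, no fluoro compound has been measured, so these steps offer only indirect guidance. No step beyond the scatter is expected in this assay in either direction. The expected step is a 1.1-fold higher number from compound 1 to compound 4 (0.05 log units; within the scatter) as estimated here. The value expected for compound 4 is an estimated 8000 nM within a range from 3500 nM to 18000 nM in this series.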

Compound 4, half-maximal inhibitory concentration: 3220 nM
Beside the measured number, compound 4's estimate is 2.5-fold (0.40 log units) above it; the whole stated range lies above it.
By their numbers in this assay, from the lowest: compounds 4, 3, 1 and 2 (each within the scatter of the next, the first and the last beyond it).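

In this assay, within the data shown here, 2,4-difluorophenyl is the first group at this place, on a saturated chain carbon bound to a nitrogen on an aromatic ring, to move the number beyond the scatter from compound 1 (a 2.2-fold lower number from compound 1 to compound 4 (0.35 log units; beyond the scatter)). The step against the 4-chlorophenyl group is the largest in this small set, though still modest (a 3.6-fold lower number from compound 2 to compound 4 (0.56 log units; beyond the scatter)), while the 4-bromophenyl group cannot be separated from 2,4-difluorophenyl (a 1.3-fold lower number from compound 3 to compound 4 (0.11 log units; within the scatter)). No measurement shown here accounts for these differences.

The compounds shown leave open whether a phenyl carrying a single fluoro would group with compound 4 or with the chloro compounds. They also leave open what a methoxy group, an amine or a carboxylic acid on this phenyl ring would give in this assay.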